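Methoxy for Fluoro on the Shared Core

The compounds below may be only part of what the source reports. "The series", "measured", "known", "first", "only" and "open" are said of these compounds alone.

Compound 1 `Clc1cccc2c1C=C(CC1CN=CN1)CC2` gives 50.1 nM in a functional assay for binding affinity to Norepinephrine transporter (Rattus norvegicus), read by radioligand binding, in the presence of a further agent that is not named here; on this read-out higher numbers stand for weaker inhibition and lower numbers for stronger inhibition.
Compound 2 `COc1cccc2c1C=C(CC1CN=CN1)CC2` gives 1000 nM in this assay.
Compound 3 `Fc1ccc2c(c1)C=C(CC1CN=CN1)CC2` gives 50.1 nM in this assay.

Compound 3 stands level with compound 1 at the digits shown, and together they are the lowest of the three numbers; compound 2 stands well above both, the step being a 20-fold higher number from compound 1 to compound 2 (1.30 log units; beyond the scatter).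

Compound 4 `COc1ccc2c(c1)C=C(CC1CN=CN1)CC2` differs from compound 3 by methoxy in place of fluoro on an aromatic carbon. Going by the values given here, the only measured step that bears on this change is a 20-fold higher number from compound 1 to compound 2 (1.30 log units; beyond the scatter), methoxy replacing a halogen on the same ring, although there it replaced chloro at another carbon. A weakening step of similar kind is therefore expected for compound 4 in this assay, namely a 10-fold higher number from compound 3 to compound 4 (1.00 log units; beyond the scatter). Compound 4 is estimated at 500 nM, with a range from 150 nM to 2000 nM.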

Compound 4, inhibition constant: < 1000 nM
Compound 4: a limit, no number; the forecaster's own chance of this, stated with the estimate: 5%; the middle value lies beyond the limit too.
By their numbers in this assay, from the lowest: compounds 1 and 3 (each within the scatter of the next); then compound 2.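

Going by these compounds alone, compound 4 gives < 1000 nM, which is a limit and not a number, so no step from compound 3 to compound 4 can be read. The compounds shown leave open how far, or in which direction, methoxy in place of fluoro on an aromatic carbon moves the number.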